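This account rests on a few compounds, and the source may have more. Where it says the series, first, only, none or still open, it means among the compounds named here.

Measured compounds:
- compound 1 `Cc1n[nH]c2ccc(-c3nc4cnc(N5CCN(C)CC5)cn4c3Nc3ccccc3Cl)cc12`: 58.1%
- compound 2 `Cc1n[nH]c2ccc(-c3nc4cnc(N5CCN(C)CC5)cn4c3Nc3ccc(Br)cc3Cl)cc12`: 70.5%
- compound 3 `Cc1cc(Br)ccc1Nc1c(-c2ccc3[nH]nc(C)c3c2)nc2cnc(N3CCN(C)CC3)cn12`: 59.4%

In a functional assay on MV4-11 cells (Homo sapiens) for inhibition, with a stated time of 120 h, tested at 10 uM (a lower number here means less inhibition, a higher number more inhibition at the concentration tested (going by the name of the read-out)), compound 3 gives 59.4%, the second highest of the three numbers. Its nearest neighbour is compound 1, with a number 1.3 percentage points higher from compound 1 to compound 3 (within the scatter), while compound 2 sits further off, with a number 11.1 percentage points lower from compound 2 to compound 3 (beyond the scatter). The step from compound 1 to compound 2 adds one substituent and gives a number 12.4 percentage points higher from compound 1 to compound 2 (beyond the scatter).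

Compound 4 `COc1ccc(Nc2c(-c3ccc4[nH]nc(C)c4c3)nc3cnc(N4CCN(C)CC4)cn23)cc1OC` differs from compound 3 in one place: 3,4-dimethoxyphenyl in place of 4-bromo-2-methylphenyl on a nitrogen on an aromatic ring. Going by the values given here, two measured steps bear on this. The step from compound 1 to compound 2 shows that a bromo on the aryl ring raised the read-out modestly, so its loss may cost something. The step from compound 2 to compound 3 shows that methyl in place of chloro lowered the read-out modestly. Nothing measured here speaks to methoxy groups on that ring.

On this basis compound 4 is expected to give a modest drop, a number 11.4 percentage points lower from compound 3 to compound 4 (beyond the scatter), with the estimate for compound 4 in this assay being 48%, in a range from 28% to 68%.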

Compound 4, a percentage reported as inhibition, at one concentration (the size of the read-out at that concentration, not a potency): 6.27%
The estimate for compound 4 lay 41.7 percentage points above the measured number; the measured number lies below the stated range.
By their numbers in this assay, from the lowest: compound 4; then compounds 1 and 3 (each within the scatter of the next); then compound 2.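

Until now, changes to the aryl group on this nitrogen had moved the read-out in this assay only modestly or not beyond the scatter, but 3,4-dimethoxyphenyl brings a far larger fall: a number 53.1 percentage points lower from compound 3 to compound 4 (beyond the scatter), a number 64.2 percentage points lower from compound 2 to compound 4 (beyond the scatter) and a number 51.8 percentage points lower from compound 1 to compound 4 (beyond the scatter). This position is therefore much more sensitive to the choice of aryl group than the first three compounds suggested, although each of these steps replaces more than one feature of the ring at once. Nothing available here explains the fall.

It remains open whether the drop comes from the methoxy groups themselves or from the loss of the groups they replace, since no compound shown separates these changes. As far as these compounds go, how a hydroxyl or an amine on that ring would read in this assay also remains open.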